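Swapping Ethynyl for Fluoro on a Bis-trifluoromethyl Ring

The source may hold more compounds than are shown below. What is called first, only, known or untested is meant among the compounds shown, and "the series" means these compounds.

Two compounds share a benzene core carrying two trifluoromethyl groups and differ only in the third substituent. Compound 1 `O=C1C=CC(=O)N1c1cc(C(F)(F)F)cc(C(F)(F)F)c1` carries a maleimide ring; compound 2 `C#Cc1cc(C(F)(F)F)cc(C(F)(F)F)c1` carries an ethynyl group. For the measured compounds named here, in an ADME assay for pharmacokinetics, read by LC-MS, in phosphate buffer, with a stated time of 72 h, at pH 7.4, tested at 250 uM (a lower number here means that the compound disappears faster, a higher number that the compound lasts longer), compound 2 gives 1.6 h, the only actual number in this set. Compound 1 reaches only a limit of the assay, < 0.017 h, and so cannot be placed more exactly than the limit of < 0.017 h in this assay, at which 1 of the 2 values shown sits. Going by the values given here, the one measured step, an at least 94-fold higher number from compound 1 to compound 2 (1.97 log units; beyond the scatter), shows that changing the group at this position can move the half-life strongly.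

Compound 3 `Fc1cc(C(F)(F)F)cc(C(F)(F)F)c1` is the next variation: fluoro in place of ethynyl on an aromatic carbon. Among the compounds with values here, no measured pair covers this exact exchange, so the step from compound 1 to compound 2 bears on it only loosely, as the sole evidence that a smaller group at this position gave a higher number. On that footing, the expected step is a 5.0-fold higher number from compound 2 to compound 3 (0.70 log units; beyond the scatter), an increase, though with wide uncertainty. Compound 3 is therefore estimated at 8 h, within a range from 1.5 h to 40 h.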

Compound 3, half-life: > 50 h
Compound 3 gave a limit, no number; the forecaster's own chance of this, stated with the estimate: 20%; at least 6.2-fold (0.79 log units) between middle value and limit.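

In this assay, the exchange of ethynyl for fluoro gives an at least 31-fold higher number from compound 2 to compound 3 (1.49 log units; beyond the scatter), so this position still moves the half-life strongly when the maleimide ring plays no part and the exchange involves only a group of 2 heavy atoms and a single fluorine atom. For compound 3 the reading is a limit of the assay and not a number: the limit of > 50 h in this assay, at which 1 of the 3 values shown sits. Across these three compounds the half-life rises as the group shrinks from the maleimide ring to ethynyl to fluoro, and none of them goes against that order, with a full span of an at least 2900-fold higher number from compound 1 to compound 3 (3.46 log units; beyond the scatter), although three compounds are a thin basis for any pattern.

The compounds shown leave open whether this order follows the size of the group or the particular chemistry of each group, a question that a chlorine atom, a methyl group, a nitrile or an amine at the same position could help to settle. From the compounds shown here alone, what happens chemically to compound 1 and compound 2 as they disappear from the buffer also stays open.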